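Moving the Ring Nitrogen in a Urea: Expected Clearance

The source may hold more compounds than are shown below. What is called first, only, known or untested is meant among the compounds shown, and "the series" means these compounds.

Compound 1, `O=C(Nc1ccc(F)c(C(F)(F)F)c1)Nc1ccccn1`, was tested in an ADME assay on microsomes from liver (Homo sapiens) for metabolic stability, using NADPH, with a stated time of 60 min; on this read-out higher numbers stand for fast clearance and lower numbers for slow clearance. In this assay, for the measured compounds named here, compound 1 gives 188 uL/min, the only plain number obtained in this small set. Compound 2, `N#Cc1ccc(NC(=O)Nc2ccc(F)c(C(F)(F)F)c2)cc1`, is the other member; in this assay compound 2 gives < 7 uL/min, which is a limit of the assay and not a measured number. Going by the values given here, it sits at the limit of < 7 uL/min in this assay, at which 1 of the 2 values shown sits, so compound 1 stands alone as the one compound with a definite reading, and it is read as fast clearance.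

Compound 3, `O=C(Nc1ccncc1)Nc1ccc(F)c(C(F)(F)F)c1`, has not yet been measured. The change from compound 1 to compound 3 is pyridin-4-yl in place of pyridin-2-yl on an amide-type nitrogen. Among the compounds with values here, since the two rings hold the same atoms joined differently, no measured step between any two compounds here shows how such a move affects clearance.

The expectation is a modest fall in clearance, at the edge of the usual scatter, with a step of a 1.9-fold lower number from compound 1 to compound 3 (0.27 log units; within the scatter). Compound 3 is therefore estimated to give 100 uL/min in this assay, with a plausible range from 40 uL/min to 250 uL/min.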

Compound 3, intrinsic clearance in a liver preparation (reported as CLH), per the amount of preparation that the assay uses in the Homo sapiens assay: 12 uL/min
Beside the measured number, compound 3's estimate is 8.3-fold (0.92 log units) above it; measured number below the stated range.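

In the Homo sapiens assay, the change of pyridin-2-yl to pyridin-4-yl on an amide-type nitrogen gives a 16-fold lower number from compound 1 to compound 3 (1.19 log units; beyond the scatter), so this position responds strongly even when no atom is added or removed and only the place of the ring nitrogen differs. For the compounds shown here, in a physicochemical assay for solubility, read by nephelometry, in phosphate buffer, measured as kinetic solubility, at pH 6.5 (a higher number here means a more soluble compound, a lower number a less soluble compound), compound 1 gives < 1.6 ug/mL, which is a limit of the assay and not a number: the limit of < 1.6 ug/mL in the physicochemical assay, at which 1 of the 2 values shown sits. In the physicochemical assay, compound 3 gives 6.3 ug/mL, and the same change therefore also appears as an at least 3.9-fold higher number from compound 1 to compound 3 (0.59 log units; beyond the scatter), meaning that the one swap moves both read-outs in the favourable direction.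

Going by these compounds alone, with only this pair of ring isomers, the numbers show that the swap matters but give no reason why, and nothing here tells whether pyridin-3-yl in the same place on the amide-type nitrogen would behave like pyridin-2-yl, like pyridin-4-yl or like neither. On these data alone, it also remains open whether a further group on the pyridin-4-yl ring, such as an amine or a methoxy group, would keep clearance slow while raising the solubility reading further.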